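The source may hold more compounds than are shown below. What is called first, only, known or untested is meant among the compounds shown, and "the series" means these compounds.

Measured in a functional assay on KYSE-70 cells for antiproliferative activity against KYSE-70 cell line (Homo sapiens), read by MTT assay, with a stated time of 72 h; a higher number here means a weaker inhibitor, a lower number a stronger inhibitor:
- compound 1 `COc1ccc(-c2ccc3c(C(=O)Nc4cccc(F)c4)cc(=O)[nH]c3c2)cc1`: > 20000 nM (a limit)
- compound 2 `O=C(Nc1cccc(F)c1)c1cc(=O)[nH]c2cc(-c3ccsc3)ccc12`: 5100 nM
- compound 3 `O=C(Nc1cccc(F)c1)c1cc(=O)[nH]c2cc(-c3ccccc3F)ccc12`: > 20000 nM (a limit)

Compound 3 gives no number, only a limit, and stands at the limit of > 20000 nM in this assay, at which 2 of the 3 values shown sit.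

Compound 4 `Nc1ccc(-c2ccc3c(C(=O)Nc4cccc(F)c4)cc(=O)[nH]c3c2)cc1` carries 4-aminophenyl in place of 2-fluorophenyl on an aromatic carbon.

The measured steps at this same place are an at least 3.9-fold lower number from compound 1 to compound 2 (0.59 log units; beyond the scatter) and an at least 3.9-fold higher number from compound 2 to compound 3 (0.59 log units; beyond the scatter), both beyond the scatter. The step that the two limits leave unreadable from compound 1 to compound 3 cannot be sized, so nothing is known about how substituted phenyl groups differ here. Thiophen-3-yl alone has given a number so far, and both phenyl-bearing compounds end at the limit. Compound 4 keeps a phenyl ring, so it is expected to remain weak, with a real chance of another limit. A gain no larger than the one seen in an at least 3.9-fold lower number from compound 1 to compound 2 (0.59 log units; beyond the scatter) is expected, and the expected step is an at least 2.0-fold lower number from compound 3 to compound 4 (0.30 log units; that floor lies within the scatter). The estimate for compound 4 is 10000 nM, with an expected range of 3000 nM to 30000 nM.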

Compound 4, half-maximal inhibitory concentration: > 20000 nM
Compound 4: a limit, no number; the forecaster's own chance of this, stated with the estimate: 40%; middle value at least 2.0-fold (0.30 log units) from the limit.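

In this assay compound 4 gives > 20000 nM, which is a limit and not a number. Thiophen-3-yl remains the only group at this place with a number, and 4-aminophenyl in its place gives an at least 3.9-fold higher number from compound 2 to compound 4 (0.59 log units; beyond the scatter). The steps among compound 1, compound 3 and compound 4 cannot be read, and these three phenyl-bearing compounds, now including one with an amino group, share a single limit: the limit of > 20000 nM in this assay, at which 3 of the 4 values shown sit.

Left open is whether the number for compound 2 depends on the sulfur of thiophen-3-yl, which furan-3-yl at this place would test. Also open, as far as these compounds go, is whether any substituted phenyl group, for instance one carrying a carboxylic acid, gives a number here at all.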